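The compounds below may be only part of what the source reports. "The series", "measured", "known", "first", "only" and "open" are said of these compounds alone.

Compound 1 `COc1cc(-c2cccc3nc(-c4cccc(Cl)c4)oc23)cc(OC)c1OC` carries a 3-chlorophenyl group on the shared core. In a functional assay on A549 cells (Homo sapiens) for antiproliferative activity, read by MTT assay, with a stated time of 48 h (on this read-out lower numbers stand for stronger inhibition and higher numbers for weaker inhibition), compound 1 gives > 25000 nM, which is a limit of the assay and not a measured number. Compound 1 therefore stands at the limit of > 25000 nM in this assay, at which 1 of the 3 values shown sits. Compound 2 `COc1cc(-c2cccc3nc(-c4cccc(C)c4)oc23)cc(OC)c1OC` has a methyl group where compound 1 has chlorine. In this assay compound 2 gives 16700 nM. Among the measured compounds shown here, the step of an at least 1.4-fold lower number from compound 1 to compound 2 (0.17 log units; that floor lies within the scatter) is the only measured change at this part of the molecule, and it does not reach beyond the usual scatter. Compound 3 `COc1ccc(-c2cccc3nc(-c4ccc5cc[nH]c5c4)oc23)c(OC)c1OC` gives 9600 nM in this assay; it differs from compound 1 in more than one place, so its value can only be set beside that of compound 1 without any single step being drawn between them.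

Compound 4 `COc1cc(-c2cccc3nc(-c4cccs4)oc23)cc(OC)c1OC` has not yet been measured. It differs from compound 1 by thiophen-2-yl in place of 3-chlorophenyl on an aromatic carbon. For the measured compounds named here, no measured step exchanges one ring for another at this place, and the one measured change there, the step of an at least 1.4-fold lower number from compound 1 to compound 2 (0.17 log units; that floor lies within the scatter), shows only a small shift. The expected step of an at least 1.2-fold lower number from compound 1 to compound 4 (0.09 log units; that floor lies within the scatter) is therefore small and may fall in either direction. Compound 4 is estimated at 20000 nM, with a range from 6000 nM to 60000 nM.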

Compound 4, half-maximal inhibitory concentration: 12500 nM
The estimate for compound 4 lay 1.6-fold (0.20 log units) above the measured number, and the stated range covers the measured number.
By their numbers in this assay, from the lowest: compounds 3, 4 and 2 (each within the scatter of the next). At a limit, above all of these: compound 1.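

Thiophen-2-yl gives the first measured exchange of one whole ring for another at this position, where the earlier step changed only a single group on the phenyl ring, and in this assay the change gives an at least 2.0-fold lower number from compound 1 to compound 4 (0.30 log units; that floor lies within the scatter). The comparison with a measured partner is firmer, and replacing 3-methylphenyl with the smaller five-membered ring containing sulfur gives a 1.3-fold lower number from compound 2 to compound 4 (0.13 log units; within the scatter), so the two rings cannot be told apart here and this position accepts either without a change beyond the scatter. The true size of the first step remains unknown, as compound 1 is known only by a limit of the assay: the limit of > 25000 nM in this assay, at which 1 of the 4 values shown sits.

All the groups shown at this position are single aromatic rings or, in compound 3, a larger ring system, and compound 3 also differs elsewhere, so it gives no clean step. As far as these compounds go, it remains open whether a basic amine on the phenyl ring, a carboxylic acid in that same place, or a longer alkyl chain in place of the ring would move the number beyond the scatter in either direction.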